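A Smaller Aryl Group in Place of Naphthalenyl

The compounds below may be only part of what the source reports. "The series", "measured", "known", "first", "only" and "open" are said of these compounds alone.

Three compounds have been tested in a functional assay on MCF7 cells (Homo sapiens) for inhibition, read by MTT assay, with a stated time of 24 h; a lower number here means a stronger inhibitor, a higher number a weaker inhibitor:
Compound 3, `CCOC(=O)C1=Cc2ccccc2OC1(OCc1cc(-c2ccc3ccccc3c2)no1)C(F)(F)F`, gives 65400 nM.
Compound 1, `CCOC(=O)C1=Cc2ccccc2OC1(OCc1cc(-c2ccc(C)cc2)no1)C(F)(F)F`, reaches only the limit > 150000 nM.
Compound 2, `CCOC(=O)C1=Cc2ccccc2OC1(OCc1cn(CC(=O)Nc2ccc(C)cc2)nn1)C(F)(F)F`, likewise reaches only the limit > 150000 nM.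

Within the data shown here, compound 3 stands as the only real number among the three; the other two are limits, as the limit of > 150000 nM in this assay, at which 2 of the 3 values shown sit, records. Compound 4, `CCOC(=O)C1=Cc2ccccc2OC1(OCc1cc(-c2ccc(Cl)cc2)no1)C(F)(F)F`, changes compound 3 in one place: 4-chlorophenyl in place of naphthalen-2-yl on an aromatic carbon. Among the measured compounds shown here, the one measured step that bears on this, an at least 2.2-fold lower number from compound 1 to compound 3 (0.36 log units; beyond the scatter), runs the other way: the 4-methylphenyl group gave a limit where the naphthalen-2-yl group gave a number. Compound 4 carries a group with one six-membered aromatic ring of similar kind, so the expected step is a 1.8-fold higher number from compound 3 to compound 4 (0.26 log units; within the scatter), toward a weaker inhibitor, with a fair chance that this assay again returns only a limit. The estimate for compound 4 is 120000 nM, within 50000 nM to 300000 nM.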

Compound 4, half-maximal inhibitory concentration: 18200 nM
The estimate for compound 4 lay 6.6-fold (0.82 log units) above the measured number; the measured number lies below the stated range.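

In this assay the smaller group gives the better result, with a 3.6-fold lower number from compound 3 to compound 4 (0.56 log units; beyond the scatter), so a second aromatic ring is not needed on this carbon. The substituent on the single ring also counts, with an at least 8.2-fold lower number from compound 1 to compound 4 (0.91 log units; beyond the scatter). Compound 1 gives only a limit, so that second step is a bound and not a full size: the limit of > 150000 nM in this assay, at which 2 of the 4 values shown sit.

Going by these compounds, whether bromo or an amine in place of the chloro of 4-chlorophenyl would lower the number further stays open. So does whether the chloro gain would carry over to other cores.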